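This account rests on a few compounds, and the source may have more. Where it says the series, first, only, none or still open, it means among the compounds named here.

Working notes on the amide series, in which the shared core stays fixed and the group on the amide nitrogen varies. In a functional assay on PC-3 cells (Homo sapiens) for antiproliferative activity, read by MTT assay, with a stated time of 24 h (a higher number here means a weaker inhibitor, a lower number a stronger inhibitor), compound 1 (`CCn1c(C(=O)NC(C)(C)CO)ccc1C(CC)(CC)c1ccc(OCS(=O)(=O)c2ccccc2)c(C)c1`) gives 9850 nM while compound 2 (`CCn1c(C(=O)N[C@H](CO)C(C)C)ccc1C(CC)(CC)c1ccc(OCS(=O)(=O)c2ccccc2)c(C)c1`) gives 7300 nM and compound 3 (`CCn1c(C(=O)N[C@@H](C)C(=O)O)ccc1C(CC)(CC)c1ccc(OCS(=O)(=O)c2ccccc2)c(C)c1`) gives 16800 nM in the same read-out. Compound 3 stands close to one neighbour (a 1.7-fold higher number from compound 1 to compound 3 (0.23 log units; within the scatter)) and apart from the other (a 2.3-fold higher number from compound 2 to compound 3 (0.36 log units; beyond the scatter)). Compound 4 (`CCn1c(C(=O)NCC(=O)O)ccc1C(CC)(CC)c1ccc(OCS(=O)(=O)c2ccccc2)c(C)c1`) differs from compound 3 by hydrogen in place of methyl on a saturated chain carbon bound to an amide-type nitrogen and a carbonyl carbon as 1-carboxyethyl becomes carboxymethyl. Among the compounds with values here, no measured pair isolates this loss of methyl. The available steps swap the whole amide substituent, and the remaining one (a 1.3-fold lower number from compound 1 to compound 2 (0.13 log units; within the scatter)) also lies within the scatter, so only one of the three is beyond it and that one is modest. No step beyond the scatter is therefore expected in this assay and neither direction is favoured. The expected change is a 1.0-fold higher number from compound 3 to compound 4 (0.01 log units; within the scatter) and it is estimated to stay within the scatter. For compound 4 the estimated value is 17000 nM with an expected range from 8000 nM to 35000 nM in this read-out.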

Compound 4, half-maximal inhibitory concentration: 30100 nM
The estimate for compound 4 lay 1.8-fold (0.25 log units) below the measured number; the measured number falls inside the stated range.
By their numbers in this assay, from the lowest: compounds 2, 1, 3 and 4 (each within the scatter of the next, the first and the last beyond it).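

In this assay, the methyl on a saturated chain carbon bound to an amide-type nitrogen and a carbonyl carbon is now tested as a single change: a 1.8-fold higher number from compound 3 to compound 4 (0.25 log units; within the scatter), so its removal from 1-carboxyethyl is not resolved from the scatter. Carboxymethyl stands apart from both hydroxymethyl-bearing amide substituents, with a 3.1-fold higher number from compound 1 to compound 4 (0.49 log units; beyond the scatter) and a 4.1-fold higher number from compound 2 to compound 4 (0.62 log units; beyond the scatter), whereas 1-carboxyethyl stood apart only from 1-(hydroxymethyl)-2-methylpropyl. Nothing at hand gives a reason for these steps.

Going by these compounds, whether a longer chain at this carbon, such as 1-carboxypropyl, would shift the number remains open. Also open, on these data alone, is what an amine or a primary amide in place of the carboxylic acid would do on the same carboxymethyl frame.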